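A few compounds are considered here, and "the series" means these few. Any claim that something is new, unique, unknown or untested is made for them only; others in the source may bear on it.

Compound 2, `COc1ccc([C@H]2CC(c3ccc(Cl)cc3)=NN2c2ncc(Br)cn2)cc1`, was examined in a functional assay on the whole organism (strain Wistar albino) for inhibition, with Rattus norvegicus as the target, read by paw edema, with stated times of 30 min and 1.5 h, at a dose of 20 mg/kg (on this read-out lower numbers stand for less inhibition and higher numbers for more inhibition at the one dose given (going by the name of the read-out)), and in it compound 2 gives 64%. Its companion in that test is compound 1, `Cc1ccc([C@H]2CC(c3ccccc3)=NN2c2ncc(Br)cn2)cc1`, and in this assay compound 1 gives 71%. The gap between these two numbers lies within the usual scatter of repeated measurements, so neither compound can be placed above the other on this evidence. Compound 3, `Clc1ccc(C2=NN(c3ncc(Br)cn3)[C@@H](c3ccccc3)C2)cc1`, has not yet been measured. It differs from compound 2 in one place: hydrogen in place of methoxy on an aromatic carbon. Going by the values given here, nothing measured so far shows what the loss of a methoxy at this place does on its own, so the expectation rests on compound 2 alone; the step of a number 1 percentage points higher from compound 2 to compound 3 (within the scatter) is expected to stay within the scatter, in no certain direction. Compound 3 is therefore estimated to give 65%, somewhere between 52% and 78%.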

Compound 3, a percentage reported as inhibition, in the whole organism at one dose (the size of the read-out at that dose, not a potency): 71%
The estimate for compound 3 lay 6 percentage points below the measured number; the measured number falls inside the stated range.
By their numbers in this assay, from the lowest: compounds 2, 1 and 3 (each within the scatter of the next).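

Going by these compounds alone, the exchange of 4-methoxyphenyl for phenyl, on an aromatic carbon para to a large group, gives the first direct reading of this change: in this assay it amounts to a number 7 percentage points higher from compound 2 to compound 3 (within the scatter). At this place, then, the methoxy is not required for the inhibition seen at this one dose, and its removal leaves a number that cannot be told apart from that of compound 2. Nothing measured here offers an explanation for this result.

As far as these compounds go, it remains open whether other groups on this aromatic carbon, such as an amine, a carboxylic acid or a longer chain like butoxy, would also stay within the scatter or move the number clearly. With a single dose shown, it also remains open whether compound 2 and compound 3 would separate at other doses.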